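Benzyloxy for Bromo: Expected Cytotoxicity of Compound 4

The compounds below may be only part of what the source reports. "The series", "measured", "known", "first", "only" and "open" are said of these compounds alone.

Measured in an ADME assay on HEK293 cells (Homo sapiens) for cytotoxicity, read by MTT assay, with a stated time of 24 h; a lower number here means a stronger inhibitor, a higher number a weaker inhibitor:
- compound 1, `Cc1cc(O)c(C(=O)/C=C/c2ccccc2)c(-c2ccc(Br)cc2)c1C(=O)/C=C/c1ccccc1`: 30000 nM
- compound 2, `Cc1cc(O)c(C(=O)/C=C/c2ccc(F)cc2)c(-c2ccc(OCc3ccccc3)cc2)c1C(=O)/C=C/c1ccc(F)cc1`: 30000 nM
- compound 3, `Cc1cc(O)c(C(=O)/C=C/c2ccc(F)cc2)c(-c2ccc(Br)cc2)c1C(=O)/C=C/c1ccc(F)cc1`: 20000 nM

All three numbers sit close together. The values of compound 1 and compound 3 lie within the scatter of one another, and compound 1 and compound 2 read the same at the digits given. The cores of compound 1 and compound 3 differ, but that difference is not broken down here.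

Within the data shown here, the single change seen within the measured set is benzyloxy in place of bromo on an aromatic carbon. It gave a 1.5-fold higher number from compound 3 to compound 2 (0.18 log units; within the scatter), a step inside the scatter.

Compound 4, `Cc1cc(O)c(C(=O)/C=C/c2ccccc2)c(-c2ccc(OCc3ccccc3)cc2)c1C(=O)/C=C/c1ccccc1`, carries the same change against compound 1: benzyloxy in place of bromo on an aromatic carbon. The two place descriptions agree word for word, so this is the same change, seen twice in all. Among the measured compounds shown here, with only one earlier instance, the expectation rests on that step alone: compound 4 is estimated to show no change at the digits printed from compound 1 to compound 4 (within the scatter) in this assay, matching the size of a 1.5-fold higher number from compound 3 to compound 2 (0.18 log units; within the scatter) seen from compound 3 to compound 2.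

Compound 4 is therefore expected to give about 30000 nM, most likely between 15000 nM and 60000 nM.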

Compound 4, half-maximal inhibitory concentration: "not active" (no number reported)
Nothing numeric was reported for compound 4; no gap can be computed for the estimate.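

In this assay, among these compounds, compound 4 is recorded as "not active" with no number, so no step from compound 1 to compound 4 can be read. The compounds shown leave open whether benzyloxy in place of bromo on an aromatic carbon shifts the number on the core of compound 1. No measured evidence bears on this result.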